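Amide in Place of the Acid on a Known Core

The compounds below may be only part of what the source reports. "The series", "measured", "known", "first", "only" and "open" are said of these compounds alone.

Measured compounds: compound 1 is `CC(Cc1ccc(NCc2cccc(Oc3ccccc3)c2)cc1)C(=O)O` and gives 100 nM. Compound 2 is `CC(CC(=O)O)c1ccc(NCc2cccc(Oc3ccccc3)c2)cc1` and gives 126 nM. Compound 3 is `O=C(O)[C@@H]1C[C@H]1c1ccc(NCc2cccc(Oc3ccccc3)c2)cc1` and gives 562 nM.

In a functional assay on CHO cells for agonist activity at Free fatty acid receptor 1 (Homo sapiens) (a lower number here means that less compound is needed, a higher number that more compound is needed for the effect), compound 3 gives the highest number of the three, set apart from compound 2 by a 4.5-fold higher number from compound 2 to compound 3 (0.65 log units; beyond the scatter) and from compound 1 by a 5.6-fold higher number from compound 1 to compound 3 (0.75 log units; beyond the scatter). Compound 4, `CNC(=O)CCc1ccc(NCc2cccc(Oc3ccccc3)c2)cc1`, differs from compound 3 in one place: 2-(methylcarbamoyl)ethyl in place of 2-carboxycyclopropyl on an aromatic carbon. Among the measured compounds shown here, the two measured steps only show that opening the ring gave modestly lower numbers; no measured step exchanges the carboxylic acid itself, so that part of the change is untested here. Compound 4 is therefore expected to give a higher number, estimated at 3000 nM (range 700 nM to 15000 nM), a step of a 5.3-fold higher number from compound 3 to compound 4 (0.73 log units; beyond the scatter).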

Compound 4, half-maximal effective concentration: 49 nM
Estimate against measurement, compound 4: 61-fold (1.79 log units) above, outside the stated range (below it).
By their numbers in this assay, from the lowest: compound 4; then compounds 1 and 2 (each within the scatter of the next); then compound 3.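

At this place, para to a large group, a carboxylic acid proves unnecessary for activity in this assay: the 2-(methylcarbamoyl)ethyl group gives an 11-fold lower number from compound 3 to compound 4 (1.06 log units; beyond the scatter), along with a 2.6-fold lower number from compound 2 to compound 4 (0.41 log units; beyond the scatter) and a 2.0-fold lower number from compound 1 to compound 4 (0.31 log units; beyond the scatter). Compound 4 thus has the lowest number of the four, something the three acids gave no sign of. No measurement at hand accounts for this result. The step from compound 3 removes the three-membered ring and the acid together, so the share of each stays unresolved. On these data alone, whether a primary amide or a longer chain on the amide nitrogen would keep this number also remains open.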